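A few compounds are considered here, and "the series" means these few. Any claim that something is new, unique, unknown or untested is made for them only; others in the source may bear on it.

Measured compounds:
- compound 1, `CN1CCC[C@@H]1Cn1nc(Cc2ccc(F)cc2)c2ccccc2c1=O`: 63.1 nM
- compound 2, `CN(C)CCn1nc(Cc2ccc(Cl)cc2)c2ccccc2c1=O`: 158 nM

In an assay for binding affinity to Alpha-1A adrenergic receptor (Homo sapiens) (on this read-out higher numbers stand for weaker inhibition and lower numbers for stronger inhibition), compound 2 gives 158 nM, the highest of the two numbers in hand. Its nearest neighbour is compound 1, which gives 63.1 nM in this assay; the gap between the two is beyond the scatter. The two differ in more than one place, so only the two values themselves can be set side by side.

Compound 3, `CN1CCC(Cn2nc(Cc3ccc(Cl)cc3)c3ccccc3c2=O)C1`, is not yet measured. It differs from compound 2 in one place: 1-methylpyrrolidin-3-yl in place of (dimethylamino)methyl on a saturated chain carbon bound to an aromatic nitrogen. For the measured compounds named here, no step between measured compounds covers this change. Going by the values given here, compound 1, the only compound carrying a five-membered ring on this chain, gives 63.1 nM; on that basis a modest step downward in this assay is expected, of about a 1.6-fold lower number from compound 2 to compound 3 (0.20 log units; within the scatter), though it may fall within the scatter. Compound 3 is estimated at 100 nM, with a range from 35 nM to 300 nM.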

Compound 3, inhibition constant: 100 nM
Compound 3: middle estimate and measured number agree at the digits printed; measured number inside the range.
By their numbers in this assay, from the lowest: compounds 1, 3 and 2 (each within the scatter of the next, the first and the last beyond it).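

In this assay, for the compounds shown here, putting 1-methylpyrrolidin-3-yl in place of (dimethylamino)methyl on a saturated chain carbon bound to an aromatic nitrogen gives a 1.6-fold lower number from compound 2 to compound 3 (0.20 log units; within the scatter), the first step that isolates a single place. At this position, the open chain and the five-membered non-aromatic ring therefore cannot be told apart in this read-out, although the ring adds heavy atoms and leaves the counted hydrogen-bond donors, acceptors and net charge unchanged. No measured property is available to account for this step.

From the compounds shown here alone, a 1-methylpiperidin-4-yl group or a longer chain ending in dimethylamino remains open at this place. Going by these compounds alone, the exchange of chlorine for fluorine on the benzyl group also remains open, since no pair of compounds isolates it.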